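A few compounds are considered here, and "the series" means these few. Any claim that something is new, unique, unknown or untested is made for them only; others in the source may bear on it.

In a functional assay on CCRF-CEM cells (Homo sapiens) for cytotoxicity, read by propidium iodide staining, with a stated time of 48 h (a higher number here means that more compound is tolerated, a lower number that less compound is tolerated), compound 1 `O=C(CN1C(=O)S/C(=C/c2ccco2)C1=O)Nc1ccc(Cl)cc1C(F)(F)F` gives 79900 nM, while compound 2 `O=C(CN1C(=O)S/C(=C/c2ccco2)C1=O)Nc1nc2ccccc2s1` gives 1700 nM. Among the compounds with values here, compound 2 therefore holds the lower of only two numbers, which means that less of it is tolerated by the cells, and the gap between the two lies beyond the usual scatter. Compound 3 `Cc1cccc2sc(NC(=O)CN3C(=O)S/C(=C/c4ccco4)C3=O)nc12` differs from compound 2 in a single small change: methyl in place of hydrogen on an aromatic carbon. This puts a methyl in place of a hydrogen on an aromatic carbon of a six-membered aromatic ring of carbon only. Within the data shown here, no measured pair shows what such a swap does, so the expectation is cautious: no shift beyond the scatter, in either direction. The estimated step is a 1.1-fold lower number from compound 2 to compound 3 (0.05 log units; within the scatter). The half-maximal cytotoxic concentration expected for compound 3 is 1500 nM, with an estimated range of 500 nM to 5000 nM.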

Compound 3, half-maximal cytotoxic concentration: 96800 nM
Estimate against measurement, compound 3: 65-fold (1.81 log units) below; the measured number lies above the stated range.
By their numbers in this assay, from the lowest: compound 2; then compounds 1 and 3 (each within the scatter of the next).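

In this assay this position turns out to matter a great deal: methyl in place of hydrogen on an aromatic carbon of the six-membered aromatic ring of carbon only gives a 57-fold higher number from compound 2 to compound 3 (1.76 log units; beyond the scatter) and so takes the cells from tolerating little of the compound to tolerating much more. Within the data shown here, the two earlier compounds differ in more than one place, so this is the first step that ties a change in the number to a single spot, and there the smallest of carbon groups is enough to produce a large effect. Nothing measured here explains the size of this step.

From the compounds shown here alone, what remains open is whether this is specific to methyl or would also appear with another group on the same carbon, such as a fluorine atom, a methoxy group or an amine. Going by these compounds, it is also open whether a methyl on another carbon of that ring would give a similar step.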